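The source may report more compounds than this note shows. Statements on the series, on what has been measured and on what is new or still open speak of the compounds shown alone.

Among the measured compounds shown here, compound 2 `COc1ccc(N2C(=O)N(Cc3c(F)cccc3Cl)c3ccccc3S2(=O)=O)cc1OC` stands lowest of the two numbers measured so far. In an assay on HEK293 cells for displacement of a labelled ligand from Orexin receptor type 2 (Homo sapiens), read by scintillation counting, with a stated time of 90 min (on this read-out higher numbers stand for weaker inhibition and lower numbers for stronger inhibition), compound 2 gives 0.794 nM, while compound 1 `COc1ccc(N2C(=O)N(Cc3c(F)cc(F)cc3F)c3ccccc3S2(=O)=O)cc1OC` gives 2 nM. For the measured compounds named here, the one step between them, a 2.5-fold lower number from compound 1 to compound 2 (0.40 log units; beyond the scatter), exchanged one substituted phenyl for another on the benzyl group; it shows that changes on this ring can move the number, though only modestly.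

Compound 3 `COc1ccc(N2C(=O)N(Cc3c(F)cc(C)cc3Cl)c3ccccc3S2(=O)=O)cc1OC` differs from compound 2 in one place: methyl in place of hydrogen on an aromatic carbon. Going by the values given here, no measured step covers a methyl added to this ring, so the halogen exchange is the only hint, and it points to small effects at best. Compound 3 is therefore expected to give about the same number as compound 2, with a 1.0-fold higher number from compound 2 to compound 3 (0.00 log units; within the scatter) as the expected step. Compound 3 is estimated at 0.8 nM in this assay, between 0.3 nM and 2.5 nM.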

Compound 3, inhibition constant: 0.794 nM
The estimate for compound 3 lay 1.0-fold (0.00 log units) above the measured number, within the range that was stated.
By their numbers in this assay, from the lowest: compounds 2 and 3 (each within the scatter of the next); then compound 1.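

In this assay the result reads no change at the digits printed from compound 2 to compound 3 (within the scatter), so a methyl can sit on this aromatic carbon, para to a large group, without a visible change in the number. The 2-chloro-6-fluoro-4-methylphenyl group also keeps the edge over 2,4,6-trifluorophenyl, with a 2.5-fold lower number from compound 1 to compound 3 (0.40 log units; beyond the scatter), which means the added methyl does not cancel the difference between these two rings. Nothing available here explains why the methyl leaves the number as it was.

A single small group at one position says little about how much room for change this carbon allows. Going by these compounds, whether a longer chain such as ethyl, a methoxy group or an amine in the same place would also leave the number where it stands remains open.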